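The source may hold more compounds than are shown below. What is called first, only, known or untested is meant among the compounds shown, and "the series" means these compounds.

Three compounds have been measured in a functional assay for inhibition, with Homo sapiens as the target; on this read-out lower numbers stand for stronger inhibition and higher numbers for weaker inhibition:
compound 1 `c1ccc(Nc2nccc(-c3ccncc3)n2)cc1` gives 900 nM;
compound 2 `Cc1cccc(Nc2nccc(-c3ccncc3)n2)c1` gives 8800 nM;
compound 3 `c1cc(Nc2nccc(-c3ccncc3)n2)cc(OCCn2ccnc2)c1` gives 200 nM.

Compound 3 stands lowest of the three, with a 4.5-fold lower number from compound 1 to compound 3 (0.65 log units; beyond the scatter) and a 44-fold lower number from compound 2 to compound 3 (1.64 log units; beyond the scatter). Compound 4 `CN(C)c1cccc(Nc2nccc(-c3ccncc3)n2)c1` differs from compound 3 in one place: dimethylamino in place of 2-(1H-imidazol-1-yl)ethoxy on an aromatic carbon. Among the measured compounds shown here, no measured step carries exactly this exchange. The nearest guides are a 4.5-fold lower number from compound 1 to compound 3 (0.65 log units; beyond the scatter), the gain that is given up when the 2-(1H-imidazol-1-yl)ethoxy group leaves, and a 9.8-fold higher number from compound 1 to compound 2 (0.99 log units; beyond the scatter), where a methyl on an aromatic carbon raised the number. Both point to a higher number for compound 4 in this assay, beyond the scatter, as a modest step. Compound 4 is therefore expected to give 1500 nM, within 400 nM to 6000 nM, which means a 7.5-fold higher number from compound 3 to compound 4 (0.88 log units; beyond the scatter).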

Compound 4, half-maximal inhibitory concentration: 3700 nM
For compound 4 the middle estimate is 2.5-fold (0.39 log units) below the measured one; low and high end bracket the measured number.
By their numbers in this assay, from the lowest: compound 3; then compound 1; then compound 4; then compound 2.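

In this assay dimethylamino on this aromatic carbon does not keep the gain of 2-(1H-imidazol-1-yl)ethoxy (a 19-fold higher number from compound 3 to compound 4 (1.27 log units; beyond the scatter)), and it also gives up ground against hydrogen (a 4.1-fold higher number from compound 1 to compound 4 (0.61 log units; beyond the scatter)). It still does better than methyl at the same place (a 2.4-fold lower number from compound 2 to compound 4 (0.38 log units; beyond the scatter)), so the two small groups both raise the number over hydrogen but to different extents. Nothing given here explains these differences. On these data alone, it remains open whether the five-membered aromatic ring or the chain carrying it accounts for the low number of compound 3, and whether a morpholine on that chain would match it.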